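Swapping methoxy for fluoro on a stilbene scaffold

The compounds below may be only part of what the source reports. "The series", "measured", "known", "first", "only" and "open" are said of these compounds alone.

Compound 1 `COc1cccc(/C=C/c2cccc(F)c2)c1` gives 2300 nM in an assay on HepG2 cells for activation of nuclear factor erythroid 2-related factor 2 (Homo sapiens), read by a luciferase reporter, with a stated time of 5 h (on this read-out higher numbers stand for an effect only at larger amounts of compound and lower numbers for an effect already at smaller amounts), which places it second highest among the three measured numbers. Compound 3 `COc1cccc(/C=C/c2cccc(F)c2)c1OC` gives 1900 nM in this assay, and compound 2 `COc1ccc(/C=C/c2cccc(F)c2)cc1OC` gives 9500 nM. One addition of a methoxy gave a 4.1-fold higher number from compound 1 to compound 2 (0.62 log units; beyond the scatter), whereas the other addition gave a 1.2-fold lower number from compound 1 to compound 3 (0.08 log units; within the scatter). Among the measured compounds shown here, compound 4 `Fc1cccc(/C=C/c2cccc(F)c2)c1` differs from compound 1 by fluoro in place of methoxy on an aromatic carbon, a change that no measured step addresses, since both steps add a methoxy rather than exchanging one for a fluoro. The two steps do show that a methoxy at one site can be exchanged without consequence while another shifts the number modestly, so the present exchange is expected to give a step in this assay from compound 1 to compound 4 of a 1.1-fold higher number from compound 1 to compound 4 (0.05 log units; within the scatter), not clearly beyond the scatter. Compound 4 is therefore estimated at 2600 nM, within 900 nM to 7500 nM.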

Compound 4, half-maximal effective concentration: 1000 nM
Beside the measured number, compound 4's estimate is 2.6-fold (0.41 log units) above it; the range from low to high includes it.
By their numbers in this assay, from the lowest: compounds 4, 3 and 1 (each within the scatter of the next, the first and the last beyond it); then compound 2.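

At this place, on an aromatic carbon meta to a group of 9 heavy atoms, the methoxy can be given up in this assay without the number rising: fluoro in its place gives a 2.3-fold lower number from compound 1 to compound 4 (0.36 log units; beyond the scatter). The two earlier steps only added a second methoxy and left this one in place, so they could not show what happens when it goes, and this exchange also removes the hydrogen-bond acceptor counted for the methoxy. Nothing measured here offers a reason for the step.

The compounds shown leave open whether the step belongs to fluoro itself or would also come with a chloro, a hydroxyl or a plain hydrogen at this place. They also leave open how an amine or a carboxylic acid would read here, and whether the same exchange holds when the further methoxy of compound 2 or compound 3 is present.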